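Trifluoromethyl for Methoxy, Carried Over to a Second Core

The source may hold more compounds than are shown below. What is called first, only, known or untested is meant among the compounds shown, and "the series" means these compounds.

Compound 2 `CCOC(=O)c1c(-c2ccc(OC)cc2)[nH]c2cc(OC)ccc2c1=O` and compound 1 `CCOC(=O)c1c(-c2ccc(C(F)(F)F)cc2)[nH]c2cc(OC)ccc2c1=O` share one core and differ in a single group on the pendant ring: trifluoromethyl in place of methoxy on an aromatic carbon. In a physicochemical assay for solubility, in phosphate buffer, at pH 7.4 (on this read-out lower numbers stand for lower solubility and higher numbers for higher solubility), compound 2 gives 8000 nM. In this assay compound 1 gives 8000 nM. The step of no change at the digits printed from compound 2 to compound 1 (within the scatter) shows that this exchange left solubility where it was.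

Compound 3 `CCOC(=O)c1c(-c2cccc(OC)c2)[nH]c2cccc(OC)c2c1=O` contains the same atoms as compound 2, joined differently; the difference between the two cores is not broken down here. In this assay compound 3 gives only a limit, > 100000 nM. That reading sits at the limit of > 100000 nM in this assay, at which 1 of the 3 values shown sits.

Compound 4 `CCOC(=O)c1c(-c2cccc(C(F)(F)F)c2)[nH]c2cccc(OC)c2c1=O` has not yet been measured. It stands to compound 3 as compound 1 stands to compound 2: trifluoromethyl in place of methoxy on an aromatic carbon. The surroundings differ, the group sitting meta to a large group here where in compound 1 it sits para to a large group, so this is the same kind of change rather than the same one. The only measured instance, no change at the digits printed from compound 2 to compound 1 (within the scatter), lay within the scatter, and nothing among the compounds shown points another way. The expected step is therefore a number no higher from compound 3 to compound 4 (the limit leaves the size open), resting on no change at the digits printed from compound 2 to compound 1 (within the scatter). Compound 4 is thus expected to give about 100000 nM in this assay, most likely between 30000 nM and 250000 nM, and it may well again return only a limit rather than a number.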

Compound 4, solubility: > 100000 nM
Compound 4 gave a limit, no number; the forecaster's own chance of this, stated with the estimate: 55%; the middle value sits exactly at the limit.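

In this assay compound 4 gives > 100000 nM, which is a limit and not a number. Compound 3 gives > 100000 nM, which is also a limit. No step can be read between compound 3 and compound 4, as both sit at the same limit: the limit of > 100000 nM in this assay, at which 2 of the 4 values shown sit. The compounds shown leave open whether trifluoromethyl in place of methoxy on an aromatic carbon moves the reading at all on the core of compound 3, and if so, how far.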